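Dichlorophenyl for methoxyphenyl on an amide side chain

The compounds below may be only part of what the source reports. "The series", "measured", "known", "first", "only" and "open" are said of these compounds alone.

Compound 1 `O=C(C/C=C/c1ccc(Cl)c(Cl)c1)Nc1nc2ccccc2c(=O)s1`: > 1000 nM
Compound 2 `COc1cccc(CCC(=O)Nc2nc3ccccc3c(=O)s2)c1`: 173 nM

Of the compounds shown here, two have been measured in an assay on CHO cells for displacement of a labelled ligand from adenosine receptor A3 (Homo sapiens), read by scintillation counting, with a stated time of 60 min; on this read-out lower numbers stand for stronger inhibition and higher numbers for weaker inhibition. Compound 1 `O=C(C/C=C/c1ccc(Cl)c(Cl)c1)Nc1nc2ccccc2c(=O)s1` gives > 1000 nM in this assay, which is a limit of the assay and not a number. Compound 2 `COc1cccc(CCC(=O)Nc2nc3ccccc3c(=O)s2)c1` gives 173 nM in this assay. Among the entries shown, this is the only one that is a number. Among the measured compounds shown here, no step between measured compounds can be counted here.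

Compound 3 `O=C(CCc1ccc(Cl)c(Cl)c1)Nc1nc2ccccc2c(=O)s1` has not yet been measured. Its difference from compound 2 is 3,4-dichlorophenyl in place of 3-methoxyphenyl on a saturated chain carbon, two bonds along the chain from a carbonyl carbon. For the measured compounds named here, the only other compound carrying a 3,4-dichlorophenyl group is compound 1, which sits at the limit of > 1000 nM in this assay, at which 1 of the 2 values shown sits. Going by the values given here, that limit gives no step, so the size of the change cannot be read from the data; still, compound 3 is expected to be weaker than compound 2, by a step beyond the usual scatter, as a 3.5-fold higher number from compound 2 to compound 3 (0.54 log units; beyond the scatter). Compound 3 is therefore estimated at 600 nM in this assay, in a range from 200 nM to 2000 nM.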

Compound 3, inhibition constant: > 1000 nM
Compound 3: no number, only a limit; the forecaster's own chance of this, stated with the estimate: 30%; middle value at least 1.6-fold (0.22 log units) from the limit.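

In this assay, the change from 3-methoxyphenyl to 3,4-dichlorophenyl on a saturated chain carbon, two bonds along the chain from a carbonyl carbon, can now be read directly as a single step: an at least 5.7-fold higher number from compound 2 to compound 3 (0.76 log units; beyond the scatter). On these data alone, compound 3 gives > 1000 nM, which is a limit of the assay and not a number, so the step has a lower bound only and its full size remains unknown. The 3,4-dichlorophenyl group now sits at the limit on both chains shown, the one with a double bond in compound 1 and the saturated one in compound 3: the limit of > 1000 nM in this assay, at which 2 of the 3 values shown sit.

The compounds shown do not separate the effect of removing the methoxy group from that of adding the two chlorine atoms, and a plain phenyl group on the same chain would bear on that question. Also open, as far as these compounds go, is whether a pyridine ring or a longer chain at this place would give a value close to that of compound 2, 173 nM, or one further from it.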